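The compounds below may be only part of what the source reports. "The series", "measured", "known", "first", "only" and "open" are said of these compounds alone.

Series notes. In a functional assay on K562 cells (Homo sapiens) for antiproliferative activity, read by CellTiter-Glo and CCK-8 assay, with a stated time of 72 h (a higher number here means a weaker inhibitor of growth, a lower number a stronger inhibitor of growth), compound 1 `Cc1ccc(Nc2ncc3c(n2)N(C)C(=O)N(c2cc(NC(=O)c4cccc(C(F)(F)F)c4)ccc2C)C3)cc1` gives 18 nM, the lowest of the three numbers, though both others lie within the scatter of it: compound 2 `Cc1ccc(NC(=O)c2cccc(C(F)(F)F)c2)cc1N1Cc2cnc(Nc3ccc(C)c(C(F)(F)F)c3)nc2N(C)C1=O` gives 29 nM and compound 3 `Cc1ccc(NC(=O)c2cccc(C(F)(F)F)c2)cc1N1Cc2cnc(O[C@H]3CCN(C(=O)OC(C)(C)C)C3)nc2N(C)C1=O` gives 30 nM. Within the data shown here, the one measured step at the position of interest, a 1.6-fold higher number from compound 1 to compound 2 (0.21 log units; within the scatter), was trifluoromethyl in place of hydrogen on an aromatic carbon and stayed within the scatter. Compound 4 `Cc1ccc(Nc2ncc3c(n2)N(C)C(=O)N(c2cc(NC(=O)c4cccc(C(F)(F)F)c4)ccc2C)C3)cc1N(C)C` differs from compound 1 by dimethylamino in place of hydrogen on an aromatic carbon; the same place again carries a new group. Among the measured compounds shown here, with only the step from compound 1 to compound 2 as a guide, a step of no size beyond the scatter in this assay is expected, the estimated step being a 1.3-fold higher number from compound 1 to compound 4 (0.12 log units; within the scatter). Compound 4 is therefore expected at 24 nM, within 9 nM to 65 nM.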

Compound 4, concentration for 50% growth inhibition: 28 nM
The estimate for compound 4 lay 1.2-fold (0.07 log units) below the measured number, and the stated range covers the measured number.
By their numbers in this assay, from the lowest: compounds 1, 4, 2 and 3 (each within the scatter of the next).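

In this assay, the place on the aromatic ring ortho to a methyl group now carries dimethylamino as well, both in place of hydrogen (a 1.6-fold higher number from compound 1 to compound 4 (0.19 log units; within the scatter)) and in place of trifluoromethyl (a 1.0-fold lower number from compound 2 to compound 4 (0.02 log units; within the scatter)). Hydrogen, trifluoromethyl and dimethylamino thus all lie within the scatter of one another here, so this place has yet to show a step beyond the scatter. Nothing available explains this. Still open, as far as these compounds go, is whether a carboxylic acid, a morpholine ring or a longer chain at this place would give a step beyond the scatter.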